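This account rests on a few compounds, and the source may have more. Where it says the series, first, only, none or still open, it means among the compounds named here.

In a functional assay on 4T1 cells (Mus musculus) for cytotoxicity, read by MTT assay, with a stated time of 24 h (a higher number here means a weaker inhibitor, a lower number a stronger inhibitor), compound 1 `COc1ccc(/C=C2\CN(C(=S)SCc3cn(Cc4ccccc4F)nn3)C/C(=C\c3ccc(OC)cc3)C2=O)cc1` gives 49900 nM on this small set. Compound 3 `Cc1ccc(/C=C2\CN(C(=S)SCc3cn(Cc4cccc(Cl)c4)nn3)C/C(=C\c3ccc(C)cc3)C2=O)cc1` gives 53400 nM in this assay as well. Compound 2 `COc1ccc(/C=C2\CN(C(=S)SCc3cn(Cc4ccc(F)cc4)nn3)C/C(=C\c3ccc(OC)cc3)C2=O)cc1` stands at the limit of > 100000 nM in this assay, at which 1 of the 3 values shown sits, and its > 100000 nM is a limit of the assay and not a number.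

Compound 4 `COc1ccc(/C=C2\CN(C(=S)SCc3cn(Cc4cccc(Cl)c4)nn3)C/C(=C\c3ccc(OC)cc3)C2=O)cc1` has not yet been measured. It changes one group of compound 2, with 3-chlorophenyl in place of 4-fluorophenyl on a saturated chain carbon bound to an aromatic nitrogen, and 3-chlorophenyl in place of 4-fluorophenyl on a saturated chain carbon bound to an aromatic nitrogen gives the count of that swap.

Among the compounds with values here, the one measured step at this place, 4-fluorophenyl in place of 2-fluorophenyl, gave an at least 2.0-fold higher number from compound 1 to compound 2 (0.30 log units; that floor lies within the scatter) as its result. A second guide is compound 3, which carries the same 3-chlorophenyl group with 53400 nM as its value, although the rest of compound 3 is not identical to compound 4.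

A step of an at least 1.6-fold lower number from compound 2 to compound 4 (0.22 log units; that floor lies within the scatter) is therefore expected in this assay toward a lower number and a stronger inhibitor, though another reading at the limit remains possible. The expected value for compound 4 is 60000 nM within an estimated range of 30000 nM to 100000 nM once it is tested.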

Compound 4, half-maximal inhibitory concentration: 69700 nM
Beside the measured number, compound 4's estimate is 1.2-fold (0.07 log units) below it, and the stated range covers the measured number.
By their numbers in this assay, from the lowest: compounds 1, 3 and 4 (each within the scatter of the next). At a limit, above all of these: compound 2.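

Compound 4 puts a third group at this place on the core shared with compound 1 and compound 2. In this assay the change to 3-chlorophenyl gives a 1.4-fold higher number from compound 1 to compound 4 (0.15 log units; within the scatter) and so cannot be told apart from 2-fluorophenyl, while the comparison with 4-fluorophenyl reads an at least 1.4-fold lower number from compound 2 to compound 4 (0.15 log units; that floor lies within the scatter) and gives only a floor for that step. Of these three groups on this core, only the 4-fluorophenyl of compound 2 stands at a limit, which is not a number: the limit of > 100000 nM in this assay, at which 1 of the 4 values shown sits.

The compounds shown leave open whether the halogen itself or its place on the ring matters, as 2-fluorophenyl and 3-chlorophenyl differ in both. They also leave open how a phenyl ring carrying an amine or a carboxylic acid, or one set on a longer chain, would read in this assay.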